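The compounds below may be only part of what the source reports. "The series", "measured", "known", "first", "only" and "open" are said of these compounds alone.

In a functional assay on HT-29 cells (Homo sapiens) for antiproliferative activity, read by sulforhodamine B assay, with a stated time of 72 h (on this read-out higher numbers stand for weaker inhibition and lower numbers for stronger inhibition), compound 1 `NC(=S)N/N=C/c1ccc2cccnc2n1` gives 12800 nM. Compound 2 `NC(=S)N/N=C/c1nc2ccccc2s1` has a different core and gives only a limit of the assay, > 100000 nM, rather than a number. Compound 3 `CN(C)C(=S)N/N=C/c1nc2ccccc2s1` keeps the core of compound 2 and carries dimethylamino in place of amino on a thiocarbonyl carbon. Within the data shown here, no measured pair of compounds shows this change, so what follows is an expectation only. A step toward stronger inhibition in this assay, beyond the usual scatter, is expected, estimated as an at least 16-fold lower number from compound 2 to compound 3 (1.22 log units; beyond the scatter). For compound 3 the estimated value is 6000 nM, with an expected range of 400 nM to 70000 nM.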

Compound 3, half-maximal inhibitory concentration: 250 nM
For compound 3 the middle estimate is 24-fold (1.38 log units) above the measured one, outside the stated range (below it).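

In this assay, dimethylamino in place of amino on a thiocarbonyl carbon gives an at least 400-fold lower number from compound 2 to compound 3 (2.60 log units; beyond the scatter), showing that this position strongly governs activity on this core. Compound 2 gives only a limit of the assay, > 100000 nM, so the step has a floor but no exact size. The change adds two carbons and removes the hydrogen-bond donor of amino, and the pair cannot separate these two differences.

On these data alone, whether methylamino or a ring amine such as piperidine would match dimethylamino stays open. So does whether the same change would act alike on the core of compound 1.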